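The source may hold more compounds than are shown below. What is called first, only, known or untested is meant among the compounds shown, and "the series" means these compounds.

Compound 3 `Cc1nc(S(C)(=O)=O)ccc1Oc1ncnc(OC2CCN(C(=S)OC(C)C)CC2)c1F` gives 1050 nM in a functional assay on isolated protein for inhibition of Glucose-dependent insulinotropic receptor (Rattus norvegicus), read by HTRF and cAMP accumulation (on this read-out higher numbers stand for an effect only at larger amounts of compound and lower numbers for an effect already at smaller amounts), the second highest of the three numbers: compound 2 `Cc1nc(S(C)(=O)=O)ccc1Oc1ncnc(OC2CCN(C(=O)O[C@@H](C)CF)CC2)c1F` gives 1680 nM, and compound 1 `Cc1nc(S(C)(=O)=O)ccc1Oc1ncnc(OC2CCN(C(=O)OC(C)(C)CF)CC2)c1F` gives 138 nM. Compound 4 `Cc1nc(S(C)(=O)=O)ccc1Oc1ncnc(OC2CCN(C(=S)OC3(C)CC3)CC2)c1F` differs from compound 3 by 1-methylcyclopropyl in place of isopropyl on an oxygen on an unsaturated carbon. The step that bears most on this is a 12-fold higher number from compound 1 to compound 2 (1.09 log units; beyond the scatter), in which a group carrying a fully substituted carbon on that oxygen was exchanged for one with a hydrogen-bearing carbon; the present change runs the other way. The steps of a 7.6-fold higher number from compound 1 to compound 3 (0.88 log units; beyond the scatter) and a 1.6-fold lower number from compound 2 to compound 3 (0.20 log units; within the scatter) concern the whole group on the amine nitrogen in a ring and bear less directly. A lower number is therefore expected for compound 4, a step of a 4.2-fold lower number from compound 3 to compound 4 (0.62 log units; beyond the scatter). Compound 4 is estimated at 250 nM, within 80 nM to 800 nM.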

Compound 4, half-maximal effective concentration: 48.8 nM
Estimate against measurement, compound 4: 5.1-fold (0.71 log units) above; the whole stated range lies above it.
By their numbers in this assay, from the lowest: compound 4; then compound 1; then compounds 3 and 2 (each within the scatter of the next).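

In this assay the exchange of isopropyl for 1-methylcyclopropyl on an oxygen on an unsaturated carbon gives a 22-fold lower number from compound 3 to compound 4 (1.33 log units; beyond the scatter) and so shows that this one group can carry a large step with the thiocarbonyl in place. Compound 4 also passes both carbonyl compounds, with a 34-fold lower number from compound 2 to compound 4 (1.54 log units; beyond the scatter) and a 2.8-fold lower number from compound 1 to compound 4 (0.45 log units; beyond the scatter) in the comparison of the whole group on the amine nitrogen in a ring. Nothing shown accounts for the size of these steps. The compounds leave open whether 1-methylcyclopropyl gives a similar step with a carbonyl instead of the thiocarbonyl, and how tert-butyl or cyclobutyl on that oxygen would read.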